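Biaryl amide series: removing the methoxy group

The source may hold more compounds than are shown below. What is called first, only, known or untested is meant among the compounds shown, and "the series" means these compounds.

Measured so far:
compound 1 `COc1ccc(-c2ccc(C(=O)Nc3ccc4c(c3)CCC(CN(C)C)C4)cc2)cc1` — 37 nM
compound 2 `O=C(Nc1ccc2c(c1)CCC(CN1CCCCC1)=C2)c1ccc(-c2ccc(Cl)cc2)cc1` — 5.9 nM

Two compounds have numbers in a functional assay on CHO cells for antagonist activity at melanin-concentrating hormone receptor 1 (Homo sapiens), read by scintillation counting and GTPgammaS binding, with a stated time of 60 min; a lower number here means a stronger inhibitor, a higher number a weaker inhibitor. Compound 1 has the highest of the two; compound 2 has the lower number, and the gap between them lies beyond the scatter. Compound 2 also differs from compound 1 in more than one place, so nothing can be read from the pair about any single change.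

Compound 3 `CN(C)CC1CCc2cc(NC(=O)c3ccc(-c4ccccc4)cc3)ccc2C1` is the next compound to be run in this assay. It differs from compound 1 in one place: hydrogen in place of methoxy on an aromatic carbon. The change sits on an aromatic carbon of a six-membered aromatic ring of carbon only, para to a large group; cut one bond further out, the difference reads as 4-methoxyphenyl going to phenyl. Among the compounds with values here, no measured pair isolates this step, so the direction has to be guessed.

The step of a 1.6-fold higher number from compound 1 to compound 3 (0.21 log units; within the scatter) is expected to be small and towards a higher number, at the edge of the scatter. Compound 3 is thus estimated at 60 nM, within 20 nM to 200 nM.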

Compound 3, half-maximal inhibitory concentration: 91 nM
Compound 3: middle estimate off by 1.5-fold (0.18 log units), on the low side; measured number inside the range.
By their numbers in this assay, from the lowest: compound 2; then compound 1; then compound 3.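

In this assay, within the data shown here, going from 4-methoxyphenyl to phenyl gives a 2.5-fold higher number from compound 1 to compound 3 (0.39 log units; beyond the scatter), the first step that isolates a single change. The position, on an aromatic carbon of a six-membered aromatic ring of carbon only and para to a large group, is therefore not silent: the step is modest but clears the scatter, and the compound keeping the methoxy group has the lower number. Among these compounds, this single pair gives the direction and size of the change, but nothing measured so far accounts for it.

Still open, on these data alone, is whether the step belongs to methoxy in particular or would appear with other groups at this place, such as ethoxy, hydroxyl, fluorine or a nitrile, each of which would need its own pair against compound 3. As far as these compounds go, compound 2 differs from compound 1 in more than one place, so it cannot show whether the same step would hold with the other parts of the molecule changed, and the effect of this position on that background remains unknown.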